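The source may report more compounds than this note shows. Statements on the series, on what has been measured and on what is new or still open speak of the compounds shown alone.

Measured so far in a functional assay on PC-3 cells (Homo sapiens) for cytotoxicity, read by sulforhodamine B assay; on this read-out higher numbers stand for lower toxicity in this test and lower numbers for higher toxicity in this test:
compound 1 `COc1cccc(OC)c1OCCNCCOc1ccccc1OCc1ccccc1`, which gives 193000 nM in this assay;
compound 2 `COc1cccc(OC)c1OCCNCCOc1ccccc1OCc1cccc(Cl)c1`, which gives 58900 nM in this assay;
compound 3 `COc1cccc(OC)c1OCCNCCOc1ccccc1OCc1ccc(Cl)cc1`, which gives 52500 nM in this assay.

Compound 3 has the lowest number of the three in this assay, but its gap to compound 2, a 1.1-fold lower number from compound 2 to compound 3 (0.05 log units; within the scatter), is within the scatter, so the two cannot be ranked; only compound 1 stands clearly apart. Compound 4 `COc1cccc(OC)c1OCCNCCOc1ccccc1OCc1ccc(C)cc1` differs from compound 3 by methyl in place of chloro on an aromatic carbon. Among the measured compounds shown here, no measured step swaps chloro for methyl. The nearest guides are a 3.3-fold lower number from compound 1 to compound 2 (0.52 log units; beyond the scatter) and a 3.7-fold lower number from compound 1 to compound 3 (0.57 log units; beyond the scatter), which show what putting in chloro did; whether methyl keeps that gain is not known from these three compounds. A step of a 1.6-fold higher number from compound 3 to compound 4 (0.21 log units; within the scatter) is expected, toward a somewhat higher number. The number for compound 4 in this assay is estimated at 85000 nM, between 35000 nM and 200000 nM.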

Compound 4, concentration lethal to 50% of the cells: 61700 nM
Beside the measured number, compound 4's estimate is 1.4-fold (0.14 log units) above it, and the stated range covers the measured number.
By their numbers in this assay, from the lowest: compounds 3, 2 and 4 (each within the scatter of the next); then compound 1.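

In this assay, exchanging the chloro for a methyl gives no difference that can be told apart (a 1.2-fold higher number from compound 3 to compound 4 (0.07 log units; within the scatter)), and compound 4 also cannot be separated from the 3-chlorophenyl compound (a 1.0-fold higher number from compound 2 to compound 4 (0.02 log units; within the scatter)). Methyl in place of hydrogen gives a step (a 3.1-fold lower number from compound 1 to compound 4 (0.50 log units; beyond the scatter)), so among these compounds the lower number does not belong to chloro alone. Nothing at hand explains this result. Still open, going by these compounds, is whether a carboxylic acid, an amine or a longer chain at this carbon would keep the lower number.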